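Ester in place of amide on the shared core

A few compounds are considered here, and "the series" means these few. Any claim that something is new, unique, unknown or untested is made for them only; others in the source may bear on it.

In an assay on CHO cells for displacement of a labelled ligand from adenosine receptor A3 (Homo sapiens), read by scintillation counting, with a stated time of 120 min, tested at 1 uM (a lower number here means less inhibition, a higher number more inhibition at the concentration tested (going by the name of the read-out)), compound 1 `N#Cc1c(N)nc(SCC(N)=O)c(C#N)c1-c1ccc(OCC2CC2)cc1` gives 8%. Compound 2 `N#Cc1c(N)nc(SCC2=NCCN2)c(C#N)c1-c1ccc(OCC2CC2)cc1` gives 6%, and compound 3 `N#Cc1c(N)nc(SCc2csc(N)n2)c(C#N)c1-c1ccc(OCC2CC2)cc1` gives 1%. Compound 1 sits at the top of the three numbers, yet the steps of a number 2 percentage points lower from compound 1 to compound 2 (within the scatter) and a number 7 percentage points lower from compound 1 to compound 3 (within the scatter) show that none of the three is set apart from another; the step of a number 5 percentage points lower from compound 2 to compound 3 (within the scatter) says the same.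

Compound 4 `COC(=O)CSc1nc(N)c(C#N)c(-c2ccc(OCC3CC3)cc2)c1C#N` differs from compound 1 by methoxy in place of amino on a carbonyl carbon. Every measured step replaced the whole carbamoyl group on the saturated chain carbon bound to a sulfur with a ring, and each of those steps stayed within the scatter. Within the data shown here, no measured step changes only the substituent on the carbonyl carbon, so none bears directly on this change. With all three measured compounds lying close together in this assay, the account expects no step beyond the scatter for compound 4, which is estimated at 7%, between 0% and 20%, corresponding to an expected step of a number 1 percentage points lower from compound 1 to compound 4 (within the scatter).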

Compound 4, a percentage reported as inhibition, at one concentration (the size of the read-out at that concentration, not a potency): 1%
Beside the measured number, compound 4's estimate is 6 percentage points above it; measured number inside the range.
By their numbers in this assay, from the lowest: compounds 3, 4, 2 and 1 (each within the scatter of the next).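

In this assay, among these compounds, the step of a number 7 percentage points lower from compound 1 to compound 4 (within the scatter) is the first measured change confined to the substituent on a carbonyl carbon, and methoxy in place of amino does not move the read-out beyond the scatter. The further steps no change at the digits printed from compound 3 to compound 4 (within the scatter) and a number 5 percentage points lower from compound 2 to compound 4 (within the scatter) show that methoxycarbonyl, which has no ring, is not set apart from the ring-bearing groups on the saturated chain carbon bound to a sulfur. No measured evidence is available here to account for these results.

The compounds shown leave open whether any other substituent on this carbonyl carbon, such as the hydroxyl of a carboxylic acid, a dimethylamino group or a longer ethoxy chain, would give a step beyond the scatter. They also leave open whether the four compounds would separate at a concentration other than the one tested.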